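The source may hold more compounds than are shown below. What is called first, only, known or untested is meant among the compounds shown, and "the series" means these compounds.

Working notes on the series. The three measured compounds share a core carrying a methyl-bearing pyrazole nitrogen and a urea link to a dichloro- or chloro-diethylamino-pyridine, and all three were run in a functional assay on HCT-116 cells (Homo sapiens) for cytotoxicity, read by MTT assay, with a stated time of 48 h, in the presence of a further agent that is not named here; a higher number here means that more compound is needed for the effect, a lower number that less compound is needed. Compound 1 `CCN(CC)c1cc(NC(=O)NNc2cc(-c3ccc(F)cc3)c3cnn(C)c3n2)cc(Cl)n1` gives 29400 nM. Compound 2 `Cc1nn(C)c2nc(NNC(=O)Nc3cc(Cl)nc(Cl)c3)cc(-c3ccc(F)cc3)c12` gives 25200 nM. Compound 3 `COc1ccc(-c2cc(NNC(=O)Nc3cc(Cl)nc(Cl)c3)nc3c2cnn3C)cc1` gives 12300 nM. Compound 2 holds the second highest of the three numbers: its value and that of compound 1 sit within the scatter of each other, so nothing separates them, while compound 3 shows a lower number that lies beyond the scatter.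

The unmeasured compound 4 `CCCc1cc(NNC(=O)Nc2cc(Cl)nc(Cl)c2)nc2c1c(C)nn2C` is compound 2 with propyl in place of 4-fluorophenyl on an aromatic carbon. Among the compounds with values here, no measured pair in this set covers that change, so there is no step to lean on; the only anchor is compound 2 at 25200 nM. The change is large in what leaves and small in what enters, and a step of moderate size toward a higher number, beyond the scatter, is the expectation here, though the direction rests on judgement rather than on a shown step. Compound 4 is accordingly expected at 45000 nM in this assay, with a range from 15000 nM to 130000 nM. The expected step of a 1.8-fold higher number from compound 2 to compound 4 (0.25 log units; within the scatter) is thus a rise, with the possibility that the assay reports only a limit.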

Compound 4, half-maximal effective concentration: 72200 nM
Compound 4: the middle estimate sits 1.6-fold (0.21 log units) below what was measured; low and high end bracket the measured number.
By their numbers in this assay, from the lowest: compound 3; then compounds 2 and 1 (each within the scatter of the next); then compound 4.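

In this assay, the position opposite the ring nitrogen now has a step of its own: the exchange of 4-fluorophenyl for propyl gives a 2.9-fold higher number from compound 2 to compound 4 (0.46 log units; beyond the scatter) and so shows that this position is not indifferent to what it carries. Compounds 1, 2 and 3 could not show this, as no two of them differ in one place alone, whereas this pair gives the series its first single-change reading, from a six-membered aromatic ring of carbon only to a chain with no ring. The data give no measured reason for the rise, and this one step does not separate the loss of the ring from the loss of the fluorine or from the smaller number of heavy atoms.

Still open, from the compounds shown here alone, is which of these features the step follows, a question that an unsubstituted phenyl, a cyclohexyl ring or a longer chain such as hexyl at this position would help to answer. Also open, going by these compounds, are how an amine or a carboxylic acid would fare there, and whether the same exchange gives a step of similar size on the core of compound 1 or compound 3.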